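Ethoxy to methoxy on the acid-bearing quinoline amide series

A few compounds are considered here, and "the series" means these few. Any claim that something is new, unique, unknown or untested is made for them only; others in the source may bear on it.

Compound 1 `Cc1ccc2nc(C(=O)Nc3c(F)cc(-c4cccc(F)c4)cc3F)c(C)c(O)c2c1` and compound 2 `CCc1ccc2nc(C(=O)Nc3c(F)cc(-c4cccc(F)c4)cc3F)c(C)c(O)c2c1` share one core; compound 3 `CCOc1ccc2nc(C(=O)Nc3c(F)cc(-c4cccc(F)c4)cc3F)c(C)c(C(=O)O)c2c1` carries another, and the difference between the two cores is not broken down here. In a functional assay on A-375 cells (Homo sapiens) for antiproliferative activity, read by MTT assay, with a stated time of 24 h, tested at 0.02 ug/mL (on this read-out lower numbers stand for a weaker effect and higher numbers for a stronger effect at the one concentration tested), compound 1 gives 0.38%, compound 2 gives -0.12% and compound 3 gives 1.02%. The change hydrogen in place of methyl on a saturated chain carbon bound to an aromatic carbon gave a number 0.5 percentage points higher from compound 2 to compound 1 (within the scatter). Compound 4 `COc1ccc2nc(C(=O)Nc3c(F)cc(-c4cccc(F)c4)cc3F)c(C)c(C(=O)O)c2c1` arises from compound 3 by hydrogen in place of methyl on a saturated chain carbon bound to an oxygen on an aromatic ring. This is the same kind of change, not the same: in compound 1 the place is on a saturated chain carbon bound to an aromatic carbon, in compound 4 on a saturated chain carbon bound to an oxygen on an aromatic ring. Given that compound 2 to compound 1 stayed within the scatter, a step of about a number 0 percentage points lower from compound 3 to compound 4 (within the scatter) is expected. Compound 4 is estimated at 1% in this assay, between -4% and 6%.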

Compound 4, a percentage reported as inhibition, at one concentration (the size of the read-out at that concentration, not a potency): 0.13%
For compound 4 the middle estimate is 0.9 percentage points above the measured one; the measured number falls inside the stated range.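

Going from ethoxy to methoxy gives a number 0.9 percentage points lower from compound 3 to compound 4 (within the scatter) in this assay. This does not show that the change would carry over to a compound with a larger read-out, since both steps start from small numbers at the one concentration tested, and the two places of change are not identical. Within that limit, hydrogen in place of methyl reads no differently on the two cores: the same change on two cores in this assay, a number 0.5 percentage points higher (within the scatter) from compound 2 to compound 1 and a number 0.9 percentage points lower (within the scatter) from compound 3 to compound 4, 1.4 percentage points apart, within the scatter of two such steps

Open, going by these compounds, is whether a longer chain than ethoxy, or an amine in place of the ethoxy or methoxy group, would move the read-out beyond the scatter on the core of compound 3. Also open, on these data alone, is how either group would read on the core of compound 1.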